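Cytotoxicity in HT-29 cells: a propyl-to-oxanyl swap

This account rests on a few compounds, and the source may have more. Where it says the series, first, only, none or still open, it means among the compounds named here.

Compound 1 `CCn1nc(C(=O)N[C@H]2COc3ccccc3N(C)C2=S)nc1Cc1ccccc1` in a toxicity assay on HT-29 cells (Homo sapiens) for cytotoxicity (a lower number here means that less compound is tolerated, a higher number that more compound is tolerated), gives > 100000 nM, a limit of the assay.
Compound 2 `CCCn1nc(C(=O)N[C@H]2COc3ccccc3N(C)C2=S)nc1Cc1ccccc1` in this assay gives > 100000 nM, again a limit of the assay.
Compound 3 `CN1C(=S)[C@@H](NC(=O)c2nc(Cc3ccccc3)n(C3CCCC3)n2)COc2ccccc21` in this assay gives > 100000 nM, also a limit of the assay.

All three measured compounds share one core and differ only in the group on an aromatic nitrogen of the five-membered ring. Compound 2 stands at the same limit as the others: the limit of > 100000 nM in this assay, at which 3 of the 3 values shown sit. Among the measured compounds shown here, since no compound received a number, none of the steps between them can be sized: a step that the two limits leave unreadable from compound 1 to compound 2, a step that the two limits leave unreadable from compound 1 to compound 3 and a step that the two limits leave unreadable from compound 2 to compound 3 are all unreadable.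

Compound 4 `CN1C(=S)[C@@H](NC(=O)c2nc(Cc3ccccc3)n(C3CCOCC3)n2)COc2ccccc21` is not yet measured. It differs from compound 2 as follows: oxan-4-yl in place of propyl on an aromatic nitrogen. The step from compound 3, which carries a cyclopentyl on the same nitrogen, is the closest comparison, and compound 3 also sits at the limit.

Given that every change at this position so far stayed at the limit, no step beyond the scatter is expected. Compound 4 is therefore estimated at 150000 nM, with a range from 50000 nM to 500000 nM. This estimate means an expected step that the limit leaves unreadable from compound 2 to compound 4, most likely reported as a limit once more.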

Compound 4, half-maximal cytotoxic concentration: > 100000 nM
Compound 4: a limit, no number; the forecaster's own chance of this, stated with the estimate: 85%; the middle value is on the limit's open side.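

In this assay compound 4 gives > 100000 nM, a limit of the assay and not a number. Its steps from compound 1, compound 2 and compound 3 therefore cannot be read, and all four stand together: the limit of > 100000 nM in this assay, at which 4 of the 4 values shown sit. In this assay the compounds shown leave open whether any group on this aromatic nitrogen would give a number rather than a limit.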